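Changing the Aryl Amine Group on a Shared Agonist Core

The source may report more compounds than this note shows. Statements on the series, on what has been measured and on what is new or still open speak of the compounds shown alone.

Compound 1 `COc1c(Nc2ccc(S(C)(=O)=O)cc2F)ncnc1OC1C[C@@H]2COC[C@@H](C1)N2C(=O)OC1(C)CC1`: 73%
Compound 2 `CC1(OC(=O)N2C[C@H]3COC[C@@H](C2)[C@@H]3Oc2ncnc(Nc3ccc(C#N)cc3Cl)c2F)CC1`: 92%
Compound 3 `CC1(COC(=O)N2CC3COCC(C2)C3Oc2ncnc(Nc3ccc(C#N)cc3Cl)c2F)COC1`: 41%

Of the compounds shown here, three have been measured in a functional assay on HEK293 cells for agonist activity at Glucose-dependent insulinotropic receptor (Homo sapiens), read by cAMP accumulation, with a stated time of 30 min; on this read-out lower numbers stand for smaller maximal responses and higher numbers for larger maximal responses. Compound 2 gives the highest of the three numbers, 92%. The nearest is compound 1 with 73%, a gap beyond the usual scatter; the furthest is compound 3 with 41%, also beyond the scatter. Among the compounds with values here, compound 1 and compound 3 differ from compound 2 in more than one place, so no single step between measured compounds isolates any one change.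

The next compound, compound 4 `CC1(OC(=O)N2C[C@H]3COC[C@@H](C2)[C@@H]3Oc2ncnc(Nc3ccccc3F)c2F)CC1`, differs from compound 2 in one place: 2-fluorophenyl in place of 2-chloro-4-cyanophenyl on a nitrogen on an aromatic ring. The group that leaves carries the nitrile, the only hydrogen-bond acceptor of that aryl group; the group that enters carries none and is smaller. Within the data shown here, no measured pair shows this change on its own, and compound 1 and compound 3 carry different aryl groups on cores that also differ elsewhere, so they give no direct guide.

The estimate for compound 4 in this assay is therefore a moderate decrease from compound 2, the step of a number 24 percentage points lower from compound 2 to compound 4 (beyond the scatter) being expected to lie beyond the scatter. Compound 4 is expected to give 68%, within a range of 45% to 92%.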

Compound 4, largest response reached (reported as percent of maximum), in percent of the reference or control that the assay uses: 78%
Compound 4: the middle estimate sits 10 percentage points below what was measured; the measured number falls inside the stated range.
By their numbers in this assay, from the lowest: compound 3; then compounds 1 and 4 (each within the scatter of the next); then compound 2.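

In this assay, within the data shown here, putting 2-fluorophenyl in place of 2-chloro-4-cyanophenyl on a nitrogen on an aromatic ring gives a number 14 percentage points lower from compound 2 to compound 4 (beyond the scatter) on an otherwise unchanged structure, and this is the first step in the set that isolates a single change. The step lies beyond the scatter but is modest, so this place tolerates the loss of the nitrile and the chlorine together with the gain of the fluorine, and an aryl group with fewer heavy atoms and no hydrogen-bond acceptor still gives a substantial maximal response. Nothing available explains why the response falls on this exchange.

Going by these compounds, because the nitrile, the chlorine and the fluorine all change in one step, the share of each remains unresolved, and it is open whether 2-chloro-phenyl without the nitrile or 2-fluoro-4-cyanophenyl would stand closer to compound 2. Also open, on these data alone, is how a carboxamide or a trifluoromethyl group on this aryl ring would compare, and whether this step would keep its size on another core.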